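The source may report more compounds than this note shows. Statements on the series, on what has been measured and on what is new or still open speak of the compounds shown alone.

Compound 1, `CNC(=O)C1=CC(C)(C)Oc2ccc([N+](=O)[O-])cc21`, gives 61% in a functional assay on the whole organism (muscle tissue) with Rattus norvegicus as the target; a higher number here means a larger maximal response, a lower number a smaller maximal response.
Compound 2, `CCNC(=O)C1=CC(C)(C)Oc2ccc([N+](=O)[O-])cc21`, gives 80.5% in this assay.

Compound 2 stands highest of the two numbers in this assay; its nearest neighbour is compound 1, which lies lower by a step beyond the scatter. Compound 3, `CCCNC(=O)C1=CC(C)(C)Oc2ccc([N+](=O)[O-])cc21`, has not yet been measured. It differs from compound 2 by methyl in place of hydrogen on a saturated chain carbon, two bonds along the chain from an amide-type nitrogen, so the chain on the amide-type nitrogen is lengthened by one more carbon.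

For the measured compounds named here, only one measured step bears on this change: a number 19.5 percentage points higher from compound 1 to compound 2 (beyond the scatter), where the same kind of lengthening, one bond closer to the amide-type nitrogen, raised the intrinsic activity by a modest amount beyond the scatter. Whether a second lengthening adds as much again cannot be read from two compounds alone; the account therefore expects a smaller rise, if any, and does not rule out a result within the scatter of compound 2. On that basis compound 3 is expected to give about 86% in this assay, between 66% and 100%. This estimate means an expected step of a number 5.5 percentage points higher from compound 2 to compound 3 (within the scatter).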

Compound 3, intrinsic activity: the largest response reached, in percent of the reference agonist's: 74.1%
The estimate for compound 3 lay 11.9 percentage points above the measured number, within the range that was stated.
By their numbers in this assay, from the lowest: compound 1; then compounds 3 and 2 (each within the scatter of the next).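

In this assay, the change from ethyl to propyl on the amide-type nitrogen gives a number 6.4 percentage points lower from compound 2 to compound 3 (within the scatter), so this further carbon does not repeat the clear step seen with the first lengthening, and the ethyl and propyl amides cannot be told apart here. The separation from the methyl amide survives the lengthening to propyl, with a number 13.1 percentage points higher from compound 1 to compound 3 (beyond the scatter), so across these three compounds the one difference beyond the scatter is that between the methyl amide and each of the two longer chains. Nothing available explains why the intrinsic activity tracks chain length over the first step but not the second.

The compounds shown leave open whether a longer chain, such as butyl or pentyl, would stay within the scatter of compound 2 and compound 3 or move away from them, and how a branched chain such as isopropyl or a ring such as cyclopropyl would read on the same nitrogen. They also leave open where the plain amide, with hydrogen in place of the chain, would stand relative to compound 1.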